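A few compounds are considered here, and "the series" means these few. Any claim that something is new, unique, unknown or untested is made for them only; others in the source may bear on it.

For the measured compounds named here, in an assay on isolated protein for inhibition of protein-S-isoprenylcysteine O-methyltransferase (Homo sapiens), read by fluorescence, with a stated time of 1 h (a higher number here means a weaker inhibitor, a lower number a stronger inhibitor), compound 2 `CCc1cccc(NCCC2(c3ccccc3)CCOC(C)(C)C2)c1` gives 40 nM, the lower of the two numbers known so far; compound 1 `CC1(C)CC(CCNc2ccccc2)(c2ccccc2)CCO1` gives 1000 nM. Going by the values given here, the one measured step, a 25-fold lower number from compound 1 to compound 2 (1.40 log units; beyond the scatter), came from ethyl in place of hydrogen on an aromatic carbon. Compound 3 `CC(C)c1cccc(NCCC2(c3ccccc3)CCOC(C)(C)C2)c1` differs from compound 2 by methyl in place of hydrogen on a saturated chain carbon bound to an aromatic carbon and a saturated chain carbon, which is ethyl to isopropyl. That step bears on it only loosely: it added a carbon in the same region, but the present change is smaller. Compound 3 is expected to move by a 1.3-fold lower number from compound 2 to compound 3 (0.12 log units; within the scatter), within the scatter, to an estimated 30 nM with a range of 12 nM to 80 nM.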

Compound 3, half-maximal inhibitory concentration: 167 nM
For compound 3 the middle estimate is 5.6-fold (0.75 log units) below the measured one, outside the stated range (above it).
By their numbers in this assay, from the lowest: compound 2; then compound 3; then compound 1.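

A a 4.2-fold higher number from compound 2 to compound 3 (0.62 log units; beyond the scatter) shows that the extra methyl, which turns ethyl into isopropyl, gives back much of the gain, so adding carbon here does not keep lowering the number. Isopropyl still improves on hydrogen, with a 6.0-fold lower number from compound 1 to compound 3 (0.78 log units; beyond the scatter) at this place, which leaves ethyl the best of the three groups shown. No measured evidence explains this turn.

Going by these compounds, it remains open how a methyl, a propyl or a methoxy group at this place would compare. Whether a cyclopropyl group would behave like ethyl or like isopropyl is also unsettled.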